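Replacing the Imidazole Side Chain With a Six-Membered Ring

This account rests on a few compounds, and the source may have more. Where it says the series, first, only, none or still open, it means among the compounds named here.

Compound 1 `Nc1noc2c(N3CC[C@@H](NC(=O)c4ccc(-n5cnc(CCO)c5)cc4Cl)C3)ncc(Cl)c12` carries a 4-(2-hydroxyethyl)-1H-imidazol-1-yl group on an aromatic carbon of a six-membered aromatic ring of carbon only, meta to a chloro group and para to a large group. For the measured compounds named here, in a physicochemical assay for permeability, using PAMPA, with a stated time of 5 h, tested at 5 uM (a lower number here means that the compound crosses the layer more slowly, a higher number that the compound crosses the layer faster), compound 1 gives 1.6 10^-6 cm/s, at the low end of the three numbers measured so far. Compound 2 `Nc1noc2c(N3CC[C@@H](NC(=O)c4ccc(-n5cnc6ncccc65)cc4Cl)C3)ncc(Cl)c12` gives 3.1 10^-6 cm/s in this assay, a step of a 1.9-fold higher number from compound 1 to compound 2 (0.29 log units; within the scatter). Compound 3 `Cn1cc(-c2ccc(C(=O)N[C@@H]3CCN(c4ncc(Cl)c5c(N)noc45)C3)c(Cl)c2)ccc1=O` gives 6.5 10^-6 cm/s in this assay, a step of a 4.1-fold higher number from compound 1 to compound 3 (0.61 log units; beyond the scatter); from compound 2 to compound 3 the change is a 2.1-fold higher number from compound 2 to compound 3 (0.32 log units; beyond the scatter).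

Compound 4 `Cn1cc(-c2ccc(C(=O)N[C@@H]3CCN(c4ncc(Cl)c5c(N)noc45)C3)c(Cl)c2)cnc1=O` differs from compound 1 in one place: a group of 8 heavy atoms (5 carbon, 2 nitrogen, 1 oxygen; one six-membered aromatic ring with 2 hetero atoms) in place of a group of 8 heavy atoms (5 carbon, 2 nitrogen, 1 oxygen; one five-membered aromatic ring with 2 hetero atoms), on an aromatic carbon. The entering group holds one double bond outside aromatic rings and no hydrogen-bond donor. Going by the values given here, of the measured steps, the one from compound 1 to compound 3, a 4.1-fold higher number from compound 1 to compound 3 (0.61 log units; beyond the scatter), is the closest parallel, as it also exchanged the five-membered ring for a six-membered aromatic ring carrying one oxygen; the step of a 1.9-fold higher number from compound 1 to compound 2 (0.29 log units; within the scatter) stayed within the scatter. A rise of comparable size is therefore expected in this assay, roughly a 3.1-fold higher number from compound 1 to compound 4 (0.49 log units; beyond the scatter). Compound 4 is estimated at 5 10^-6 cm/s, with a range from 2.5 10^-6 cm/s to 10 10^-6 cm/s.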

Compound 4, apparent permeability: 0.7 10^-6 cm/s
The estimate for compound 4 lay 7.1-fold (0.85 log units) above the measured number; the measured number lies below the stated range.
By their numbers in this assay, from the lowest: compound 4; then compounds 1 and 2 (each within the scatter of the next); then compound 3.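

The sharpest lesson comes from comparing compound 3 with compound 4: both groups hold the same number of heavy atoms and a six-membered aromatic ring, yet trading one carbon for one nitrogen gives the largest step seen so far in this assay (a 9.3-fold lower number from compound 3 to compound 4 (0.97 log units; beyond the scatter)). Ring size alone therefore does not set the number at this position, since going from the imidazole of compound 1 to a six-membered ring can move it either way: up in one case (a 4.1-fold higher number from compound 1 to compound 3 (0.61 log units; beyond the scatter)) and down in the other (a 2.3-fold lower number from compound 1 to compound 4 (0.36 log units; beyond the scatter)), while compound 4 also falls short of the fused group of compound 2 (a 4.4-fold lower number from compound 2 to compound 4 (0.65 log units; beyond the scatter)). No measurement at hand explains why one extra ring nitrogen has this effect.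

For the compounds shown here, with only one group of this kind carrying a second ring nitrogen, it remains unknown whether the fall depends on where that nitrogen sits in the ring. Going by these compounds, it is equally open how a plain phenyl ring, or a methoxy group or an amine on the six-membered ring, would behave at this place on the same core.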